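Ring swap on the chain: from compound 3 to compound 4

This account rests on a few compounds, and the source may have more. Where it says the series, first, only, none or still open, it means among the compounds named here.

Compound 1 `COc1ccc(C(=O)/C=C/c2ccc(N(C)C)cc2)c2c1C=CC(C)(C)O2` gives 730 nM in a functional assay on HepG2 cells (Homo sapiens) for antiproliferative activity, read by MTT assay, with a stated time of 24 h; on this read-out lower numbers stand for stronger inhibition and higher numbers for weaker inhibition. Compound 2 `COc1ccc(/C=C/C(=O)c2ccc(OC)c3c2OC(C)(C)C=C3)cn1` reaches only a limit of the method, > 10000 nM in this assay. Compound 3 `COc1ccc(C(=O)/C=C/c2ccccn2)c2c1C=CC(C)(C)O2` gives 5760 nM in this assay and so stands at the highest of the two numbers, with a 7.9-fold higher number from compound 1 to compound 3 (0.90 log units; beyond the scatter) and, against the limit, an at least 1.7-fold lower number from compound 2 to compound 3 (0.23 log units; that floor lies within the scatter). Compound 4 `COc1ccc(C(=O)/C=C/c2ccc(O)c(Br)c2)c2c1C=CC(C)(C)O2` is not yet measured; it differs from compound 3 by 3-bromo-4-hydroxyphenyl in place of pyridin-2-yl on a double-bonded chain carbon bound to a double-bonded chain carbon. Among the measured compounds shown here, the steps that bear on it are a 7.9-fold higher number from compound 1 to compound 3 (0.90 log units; beyond the scatter) and an at least 13-fold higher number from compound 1 to compound 2 (1.13 log units; beyond the scatter); both left the ring of carbon only of compound 1 and the numbers rose. Compound 4 is therefore expected to move by a 3.8-fold lower number from compound 3 to compound 4 (0.58 log units; beyond the scatter) in this assay. Compound 4 is estimated at 1500 nM, between 500 nM and 4500 nM.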

Compound 4, half-maximal inhibitory concentration: > 10000 nM
Compound 4: a limit, no number; the forecaster's own chance of this, stated with the estimate: 5%; middle value at least 6.6-fold (0.82 log units) from the limit.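

Compound 4 gives only a limit in this assay, not a number. A ring of carbon only at this place therefore does not by itself keep the activity of compound 1: an at least 13-fold higher number from compound 1 to compound 4 (1.13 log units; beyond the scatter), with 3-bromo-4-hydroxyphenyl in place of 4-(dimethylamino)phenyl. Against pyridin-2-yl the floor is only an at least 1.7-fold higher number from compound 3 to compound 4 (0.23 log units; that floor lies within the scatter), so no order can be set, and the step between compound 2 and compound 4 cannot be read: the limit of > 10000 nM in this assay, at which 2 of the 4 values shown sit.

On these data alone, it remains open whether the hydroxyl or the bromine accounts for the loss. Also open, as far as these compounds go, is whether a phenyl ring carrying a primary amine or a morpholine would hold the activity of compound 1.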